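The compounds below may be only part of what the source reports. "The series", "measured", "known", "first", "only" and "open" are said of these compounds alone.

The compounds share one core, shown in compound 2 as `COc1cc(-c2nn(-c3cccc(NC(=O)Nc4cccc(C(F)(F)F)c4)c3)cc2-c2ccncc2)ccc1Cl`. For the measured compounds named here, in a functional assay on SF-268 cells (Homo sapiens) for inhibition, read by sulforhodamine B assay, with a stated time of 48 h (a lower number here means that less compound is tolerated, a higher number that more compound is tolerated), compound 2 gives 50000 nM, which is the only plain number in this small set. Compound 1, `COc1cc(-c2nn(-c3cccc(NC(=O)Nc4ccc(Cl)c(Cl)c4)c3)cc2-c2ccncc2)ccc1Cl`, carries a 3,4-dichlorophenyl group on the amide-type nitrogen where compound 2 carries a 3-(trifluoromethyl)phenyl group. In this assay compound 1 gives > 50000 nM, a limit of the assay rather than a number. Going by the values given here, the one measured step, a number no higher from compound 1 to compound 2 (the limit leaves the size open), is therefore bounded by the limit of > 50000 nM in this assay, at which 1 of the 2 values shown sits, and has no readable size. Compound 3, `COc1cc(-c2nn(-c3cccc(NC(=O)Nc4ccc(Cl)c(C(F)(F)F)c4)c3)cc2-c2ccncc2)ccc1Cl`, differs from compound 2 by chloro in place of hydrogen on an aromatic carbon. Among the compounds with values here, since the only measured step cannot be sized, no step beyond the scatter is expected here. The step from compound 2 to compound 3 is estimated as no change at the digits printed from compound 2 to compound 3 (within the scatter). For compound 3 the expected value in this assay is 50000 nM, with a range from 20000 nM to 150000 nM.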

Compound 3, concentration lethal to 50% of the cells: > 32500 nM
Compound 3: a limit, no number; the forecaster's own chance of this, stated with the estimate: 50%; the middle value is on the limit's open side.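

In this assay compound 3 gives > 32500 nM, a limit of the assay and not a number, so its steps from compound 2 and from compound 1 cannot be read. The compounds shown leave open whether chloro in place of hydrogen on the 3-(trifluoromethyl)phenyl group changes the concentration tolerated at all.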